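The compounds below may be only part of what the source reports. "The series", "measured", "known", "first", "only" and "open" are said of these compounds alone.

Measured so far:

- compound 1, `O=S(=O)(Nc1ccc(F)cc1)c1ccc(Cl)cc1`: 8.41
- compound 2, `Cc1ccc(NS(=O)(=O)c2ccc(Cl)cc2)cc1`: 8.78
- compound 3, `O=[N+]([O-])c1ccc(S(=O)(=O)Nc2ccc(F)cc2)cc1`: 6.45

These three compounds were examined in an ADME assay. Compound 1 serves as the starting point. Compound 2 differs from compound 1 only by methyl in place of fluoro on an aromatic carbon, and this change gave a number 0.37 log units higher from compound 1 to compound 2 (beyond the scatter). Compound 3 differs from compound 1 by nitro in place of chloro on an aromatic carbon, which gave a number 1.96 log units lower from compound 1 to compound 3 (beyond the scatter), so compound 3 gives the lowest value of the three.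

Compound 4, `Cc1ccc(NS(=O)(=O)c2ccc([N+](=O)[O-])cc2)cc1`, has not yet been measured in this assay. It differs from compound 3 by methyl in place of fluoro on an aromatic carbon. This is the same change that separates compound 2 from compound 1, made at the same kind of place, and it occurs twice among these compounds. The cores of compound 1 and compound 3 differ by the nitro in place of chloro described above. Because compound 1 to compound 2 gave a number 0.37 log units higher from compound 1 to compound 2 (beyond the scatter), compound 4 is expected to sit a similar step above compound 3, namely a number 0.37 log units higher from compound 3 to compound 4 (beyond the scatter). The estimate for compound 4 in this assay is therefore 6.82, with a likely range from 6.55 to 7.1.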

Compound 4, acid dissociation constant: 6.78
The estimate for compound 4 lay 0.04 log units above the measured number; measured number inside the range.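

In this assay, methyl in place of fluoro gave a number 0.33 log units higher from compound 3 to compound 4 (beyond the scatter), which closely matches the earlier step on the other core: the same change on two cores in this assay, a number 0.37 log units higher (beyond the scatter) from compound 1 to compound 2 and a number 0.33 log units higher (beyond the scatter) from compound 3 to compound 4, 0.04 log units apart, within the scatter of two such steps. Nitro in place of chloro gave a number 2.00 log units lower from compound 2 to compound 4 (beyond the scatter), and this change also kept its size from one core to the other: the same change on two cores in this assay, a number 1.96 log units lower (beyond the scatter) from compound 1 to compound 3 and a number 2.00 log units lower (beyond the scatter) from compound 2 to compound 4, 0.04 log units apart, within the scatter of two such steps. Within these four compounds, each change therefore shifted the number by much the same amount whichever group stood in the other place, but this rests on only two cores per change and does not show that the steps would hold on any other core, nor why they match.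

These compounds carry only fluoro or methyl in one place and only chloro or nitro in the other, leaving open whether an amine, a methoxy group or a nitrile in either place would also give steps that carry over. Going by these compounds, it also remains open whether the steps would keep their size with a change elsewhere in the shared core.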